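The source may hold more compounds than are shown below. What is called first, only, known or untested is meant among the compounds shown, and "the series" means these compounds.

Compound 1 `COc1ccc(Sc2nc3cc(N)cc(N)c3nc2-c2ccccc2)cc1` — in a functional assay on IGROV-1 cells (Homo sapiens) for inhibition, read by sulforhodamine B assay, with a stated time of 48 h (on this read-out lower numbers stand for stronger inhibition of growth and higher numbers for weaker inhibition of growth), compound 1 gives < 100000 nM, which is a limit of the assay.
Compound 2 `Nc1cc(N)c2nc(-c3ccccc3)c(Oc3ccc(F)cc3)nc2c1` — in this assay compound 2 gives < 100000 nM, again only a limit.

Going by the values given here, both results sit at the limit of < 100000 nM in this assay, at which 2 of the 2 values shown sit, so the single measured step, a step that the two limits leave unreadable from compound 1 to compound 2, cannot be read. Compound 3 `Nc1cc(N)c2nc(-c3ccccc3)c(Sc3ccc(F)cc3)nc2c1` differs from compound 2 by (4-fluorophenyl)sulfanyl in place of 4-fluorophenoxy on an aromatic carbon. Among the compounds with values here, no measured step isolates a sulfur link against an oxygen link, and the one step known is hidden by the limit. Compound 3 is therefore expected to remain near the same limit, with a step that the limit leaves unreadable from compound 2 to compound 3 as the expected step. The estimate for compound 3 is 50000 nM, ranging from 5000 nM to 100000 nM.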

Compound 3, concentration for total growth inhibition: < 100000 nM
Compound 3: a limit, no number; the forecaster's own chance of this, stated with the estimate: 80%; the middle value is on the limit's open side.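

Compound 3 also gives only a limit, so no step among compound 1, compound 2 and compound 3 can be read: the limit of < 100000 nM in this assay, at which 3 of the 3 values shown sit.

Going by these compounds, whether swapping 4-fluorophenoxy for (4-fluorophenyl)sulfanyl, or methoxy for fluoro, changes growth inhibition in this assay remains open.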